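Swapping a Ring Substituent on the Piperazine Amide

This account rests on a few compounds, and the source may have more. Where it says the series, first, only, none or still open, it means among the compounds named here.

Compound 1 `CC#CC(CC(=O)O)c1ccc(OCc2ccc(C(=O)N3CCN(C)CC3)s2)cc1` was tested in a functional assay on HEK293 cells for agonist activity at Free fatty acid receptor 1 (Homo sapiens), read by fluorescence and calcium flux (a higher number here means that more compound is needed for the effect, a lower number that less compound is needed), where compound 1 reached only a limit of > 5000 nM. Among the compounds with values here, compound 2 `CC#CC(CC(=O)O)c1ccc(OCc2ccc(C(=O)N3CCN(C4CCCCC4)CC3)s2)cc1`, in this assay, gives 820 nM, the only firm number among the two values. The step of an at least 6.0-fold lower number from compound 1 to compound 2 (0.78 log units; beyond the scatter) shows that enlarging the group on the ring amine nitrogen lowered the number. Compound 3 `CC#CC(CC(=O)O)c1ccc(OCc2ccc(C(=O)N3CCN(c4ccc(OC)cc4)CC3)s2)cc1` carries the change (4-methoxyphenyl in place of cyclohexyl on an amine nitrogen in a ring). Within the data shown here, only that single measured step bears on it, and it compared a small group with a large one; here one large group replaces another, so no step beyond the scatter is expected. Compound 3 is therefore expected near 900 nM, between 300 nM and 3000 nM, with an estimated step of a 1.1-fold higher number from compound 2 to compound 3 (0.04 log units; within the scatter).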

Compound 3, half-maximal effective concentration: 289 nM
Compound 3: the middle estimate sits 3.1-fold (0.49 log units) above what was measured, outside the stated range (below it).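

In this assay, the choice among large groups on this ring amine nitrogen still matters: 4-methoxyphenyl in place of cyclohexyl gives a 2.8-fold lower number from compound 2 to compound 3 (0.45 log units; beyond the scatter). Set against methyl, the same group gives an at least 17-fold lower number from compound 1 to compound 3 (1.23 log units; beyond the scatter). That step is only a bound, as it rests on a limit for compound 1: the limit of > 5000 nM in this assay, at which 1 of the 3 values shown sits.

The change brings in an aromatic ring and an oxygen together, so the compounds shown cannot separate the two. On these data alone, whether a plain phenyl or a pyridine ring on this nitrogen would behave the same stays open.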